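The source may hold more compounds than are shown below. What is called first, only, known or untested is meant among the compounds shown, and "the series" means these compounds.

The measured compounds and their numbers:
compound 1, `O=C(/C(=C\c1ccc(Cl)cc1)Sc1ccc(Br)cc1)c1ccc(Br)cc1`: 1000 nM
compound 2, `O=C(/C(=C\c1ccc([N+](=O)[O-])c(O)c1)SCc1ccc(Br)cc1)c1cc(Cl)ccc1O`: 10000 nM
compound 3, `O=C(/C(=C\c1ccc(Cl)cc1)SCc1ccc(Cl)cc1)c1ccc(Br)cc1`: 10000 nM

All three were tested in a functional assay on DU-145 cells (Homo sapiens) for inhibition, read by trypan blue exclusion, with a stated time of 96 h; a lower number here means a stronger inhibitor of growth, a higher number a weaker inhibitor of growth. Compound 1 gives the lowest of the three numbers; compound 2 and compound 3 each give a higher number, and both gaps lie beyond the scatter. Among the compounds with values here, only one pair differs in a single place, and that step, a 10-fold higher number from compound 1 to compound 3 (1.00 log units; beyond the scatter), puts 4-chlorobenzyl in place of 4-bromophenyl on a sulfur and weakens growth inhibition.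

Compound 4, `COc1ccc(/C=C(/Sc2ccc(Br)cc2)C(=O)c2ccc(Br)cc2)c(F)c1`, has not yet been measured. It differs from compound 1 in one place: 2-fluoro-4-methoxyphenyl in place of 4-chlorophenyl on a double-bonded chain carbon bound to a double-bonded chain carbon. Within the data shown here, the one measured step alters the group on the sulfur, whereas this change alters the group on the double-bonded chain carbon, so no measured step speaks directly to it. Compound 2 carries other groups on that carbon, but it differs from compound 1 in several places at once and cannot be read as a single step. With nothing to guide the direction, the expected number for compound 4 is near that of compound 1 with wide uncertainty. Compound 4 is therefore estimated at 1500 nM, between 400 nM and 6000 nM, a step of a 1.5-fold higher number from compound 1 to compound 4 (0.18 log units; within the scatter) expected to stay within the scatter.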

Compound 4, concentration for 50% growth inhibition: 20000 nM
Compound 4: middle estimate off by 13-fold (1.12 log units), on the low side; the measured number lies above the stated range.
By their numbers in this assay, from the lowest: compound 1; then compounds 2, 3 and 4 (each within the scatter of the next).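

In this assay, the group on this double-bonded chain carbon proves to matter a great deal: putting 2-fluoro-4-methoxyphenyl in place of 4-chlorophenyl gives a 20-fold higher number from compound 1 to compound 4 (1.30 log units; beyond the scatter), the first single-place step read at this position. Within the data shown here, until now, the only single change away from compound 1 lay on the sulfur, so growth inhibition by compound 1 is now seen to depend on the group at this carbon as well, and in both single changes it weakens. This swap, however, removes the chlorine and brings in both a fluorine and a methoxy group at once, and no supporting data explain why the number rises.

The compounds shown leave open which part of the swap carries the loss, a question that simpler groups at this carbon, such as plain phenyl, 4-methoxyphenyl or 2-fluorophenyl, could help to separate. They also leave open whether any group here can give a lower number than compound 1, for example a phenyl ring bearing a carboxylic acid or 4-aminophenyl.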